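Swapping the ether side chain on compound 3

This account rests on a few compounds, and the source may have more. Where it says the series, first, only, none or still open, it means among the compounds named here.

Compound 1 `NC(=O)c1cc(-c2ccc(NS(=O)(=O)c3cccc(Cl)c3Cl)cc2)nc2[nH]ncc12` is measured in an assay for inhibition of serine/threonine-protein kinase Sgk1 (Homo sapiens), with stated times of 30 min and 60 min, in the presence of a further agent that is not named here (on this read-out higher numbers stand for weaker inhibition and lower numbers for stronger inhibition), at 1 nM. Compound 2 `CN1CC(NC(=O)c2cc(-c3ccc(NS(=O)(=O)c4cccc(Cl)c4Cl)cc3)nc3[nH]ncc23)C1` reaches the assay limit of < 1 nM, which is a limit rather than a number. Compound 3 `Cc1n[nH]c2nc(-c3ccc(NS(=O)(=O)c4cc(Cl)ccc4F)cc3)nc(OCC3(CN)COC3)c12` stands level with compound 1 in this assay; compound 3 gives 1 nM. Compound 4 `Cc1n[nH]c2nc(-c3ccc(NS(=O)(=O)c4cc(Cl)ccc4F)cc3)nc(OCC3CN(C(C)C)C3)c12` differs from compound 3 by 1-isopropylazetidin-3-yl in place of 3-(aminomethyl)oxetan-3-yl on a saturated chain carbon bound to an oxygen on an aromatic ring. Going by the values given here, the only measured step, a number no higher from compound 1 to compound 2 (the limit leaves the size open), sits at a different place on the shared core and its size cannot be read because the limit of < 1 nM in this assay, at which 1 of the 3 values shown sits, marks where compound 2 sits; nothing measured speaks directly to the change in compound 4. The expected step is therefore no change at the digits printed from compound 3 to compound 4 (within the scatter), meaning no change beyond the usual scatter. Compound 4 is estimated at 1 nM in this assay, with a range from 0.4 nM to 3 nM.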

Compound 4, half-maximal inhibitory concentration: 1 nM
For compound 4 middle estimate and measured number coincide at the digits printed, within the range that was stated.
By their numbers in this assay, from the lowest: compounds 1, 3 and 4 (each within the scatter of the next).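

Putting 1-isopropylazetidin-3-yl in place of 3-(aminomethyl)oxetan-3-yl on a saturated chain carbon bound to an oxygen on an aromatic ring gives, in this assay, no change at the digits printed from compound 3 to compound 4 (within the scatter). This position therefore holds its level with a group of 0 hydrogen-bond donors as well as with a group of 1, and with nitrogen as well as oxygen in the four-membered ring.

As far as these compounds go, whether a carboxylic acid or a longer open chain at this place would hold that level stays open. Compound 2 reaches a limit of this read-out, so a gain at this position could go unseen: the limit of < 1 nM in this assay, at which 1 of the 4 values shown sits.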